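The source may report more compounds than this note shows. Statements on the series, on what has been measured and on what is new or still open speak of the compounds shown alone.

Measured compounds in a functional assay on HEK293 cells for agonist activity at G-protein coupled receptor 39 (Homo sapiens), read by scintillation proximity assay and inositol phosphate accumulation, with a stated time of 75 min, in the presence of a further agent that is not named here; on this read-out higher numbers stand for an effect only at larger amounts of compound and lower numbers for an effect already at smaller amounts:
compound 1 `Cc1cc(C)n(CCOC2CC(=O)Nc3c2c(C)nn3-c2ncnc3nc[nH]c23)n1`, 16 nM
compound 2 `Cc1nn(-c2ncnc3nc[nH]c23)c2c1C(NC(=O)c1ccccc1)CC(=O)N2`, 3 nM

Within the data shown here, compound 2 has the lowest number of the two in this assay; the only measured step at the saturated ring carbon is a 5.3-fold lower number from compound 1 to compound 2 (0.73 log units; beyond the scatter), a modest change. Compound 3 `Cc1nn(-c2ncnc3nc[nH]c23)c2c1C(OC(=O)c1ccc(F)cc1)CC(=O)N2` carries ((4-fluorophenyl)carbonyl)oxy in place of benzamido on a saturated ring carbon. That step bears on the same place, but it swapped a whole side chain, whereas here the aryl carbonyl stays and only the link to the ring changes. A shift within or just beyond the scatter is therefore expected, toward a higher number, a 2.7-fold higher number from compound 2 to compound 3 (0.43 log units; beyond the scatter). Compound 3 is estimated at 8 nM, between 2 nM and 40 nM.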

Compound 3, half-maximal effective concentration: 4 nM
For compound 3 the middle estimate is 2.0-fold (0.30 log units) above the measured one; measured number inside the range.
By their numbers in this assay, from the lowest: compounds 2 and 3 (each within the scatter of the next); then compound 1.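

In this assay the change on the saturated ring carbon gives a 1.3-fold higher number from compound 2 to compound 3 (0.12 log units; within the scatter), so benzamido and ((4-fluorophenyl)carbonyl)oxy cannot be told apart here, even though the entering group counts 0 hydrogen-bond donors against 1. With the oxygen kept on the saturated carbon, the group it carries matters: (4-fluorophenyl)carbonyl in place of 2-(3,5-dimethyl-1H-pyrazol-1-yl)ethyl gives a 4.0-fold lower number from compound 1 to compound 3 (0.60 log units; beyond the scatter). No evidence on the cause of either step is available. From the compounds shown here alone, the step from compound 2 to compound 3 changes the link and the fluorine together, so their separate contributions remain open. Also open, going by these compounds, is whether a simple amine on this ring carbon, without the carbonyl, would give similar numbers.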